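The source may hold more compounds than are shown below. What is called first, only, known or untested is meant among the compounds shown, and "the series" means these compounds.

Among the measured compounds shown here, in a functional assay on K562 cells (Homo sapiens) for antiproliferative activity, with a stated time of 72 h (on this read-out higher numbers stand for weaker inhibition and lower numbers for stronger inhibition), compound 1 `OC[C@H]1O[C@@H](n2cnc3c(NCc4cccc(F)c4)ncnc32)[C@H](O)[C@@H]1O` gives 7600 nM and compound 2 `OC[C@H]1O[C@@H](n2cnc3c(NCc4cccc(Br)c4)ncnc32)[C@H](O)[C@@H]1O` gives 19700 nM, the higher of the two numbers so far. Compound 3 `OC[C@H]1O[C@@H](n2cnc3c(NCc4ccc(Br)cc4)ncnc32)[C@H](O)[C@@H]1O` is unmeasured and differs from compound 2 by 4-bromophenyl in place of 3-bromophenyl on a saturated chain carbon bound to a nitrogen on an aromatic ring. For the measured compounds named here, the only measured step, a 2.6-fold higher number from compound 1 to compound 2 (0.41 log units; beyond the scatter), exchanges the substituent on the aromatic carbon rather than moving it, so it bears only loosely on this change. Going by the values given here, no measured step shows what moving the bromine does. A shift of no greater size is therefore expected in this assay, most likely none beyond the scatter, with no firm direction. The estimated step is a 1.2-fold lower number from compound 2 to compound 3 (0.09 log units; within the scatter). For compound 3 the expected value is 16000 nM, with an estimated range of 6000 nM to 45000 nM.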

Compound 3, half-maximal inhibitory concentration: 68200 nM
The estimate for compound 3 lay 4.3-fold (0.63 log units) below the measured number; measured number outside the range, above it.
By their numbers in this assay, from the lowest: compound 1; then compound 2; then compound 3.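

Moving the bromine alone matters in (this assay): with the same atoms joined differently, 4-bromophenyl in place of 3-bromophenyl gives a clear loss (a 3.5-fold higher number from compound 2 to compound 3 (0.54 log units; beyond the scatter)). Against 3-fluorophenyl, the 4-bromophenyl group gives the largest step of the three compounds (a 9.0-fold higher number from compound 1 to compound 3 (0.95 log units; beyond the scatter)), so the two bromophenyl isomers are not interchangeable at this place on the saturated chain carbon. Nothing available explains the shift. From the compounds shown here alone, whether 4-fluorophenyl would shift the same way from 3-fluorophenyl stays open. So does the reading of a 4-methoxyphenyl or an unsubstituted phenyl group here.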